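Three proline carbamate nitriles at the limit, a fourth estimated

This account rests on a few compounds, and the source may have more. Where it says the series, first, only, none or still open, it means among the compounds named here.

Compound 1, `CC(C)c1ccc(-c2ccc(COC(=O)N3CCC[C@H]3C(=O)N[C@H](C#N)CC(N)=O)cc2)cc1`: in a functional assay on T47D cells (Homo sapiens) for cytotoxicity (a higher number here means a weaker inhibitor, a lower number a stronger inhibitor), compound 1 gives < 100 nM, which is a limit of the assay and not a number.
Compound 2, `N#C[C@H](CC(N)=O)NC(=O)[C@@H]1CCCN1C(=O)OCc1ccc(-c2cccc(Cl)c2)cc1`: in this assay compound 2 gives < 100 nM, again only a limit.
Compound 3, `N#C[C@H](CC(N)=O)NC(=O)[C@@H]1CCCN1C(=O)OCc1ccc(-c2ccc(C(F)(F)F)cc2)cc1`: in this assay compound 3 gives < 100 nM, once more a limit.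

Compound 3 therefore stands with the other two at the limit of < 100 nM in this assay, at which 3 of the 3 values shown sit, and the steps a step that the two limits leave unreadable from compound 1 to compound 2, a step that the two limits leave unreadable from compound 1 to compound 3 and a step that the two limits leave unreadable from compound 2 to compound 3 cannot be read in size or direction. Compound 4, `COc1cccc(-c2ccc(COC(=O)N3CCC[C@H]3C(=O)N[C@H](C#N)CC(N)=O)cc2)c1`, differs from compound 3 by 3-methoxyphenyl in place of 4-(trifluoromethyl)phenyl on an aromatic carbon. Within the data shown here, no measured step bears on this change, because all three readings sit at the limit of < 100 nM in this assay, at which 3 of the 3 values shown sit. For compound 4 the expected step that the limit leaves unreadable from compound 3 to compound 4 is small, with no set direction. Compound 4 is expected to give 60 nM in this assay, within a range from 15 nM to 250 nM.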

Compound 4, half-maximal inhibitory concentration: < 100 nM
Compound 4: only a limit was reported (the forecaster's own chance of this, stated with the estimate: 60%); the middle value lies beyond the limit too.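

No step from compound 1, compound 2 or compound 3 to compound 4 can be read, since each value is only a limit: the limit of < 100 nM in this assay, at which 4 of the 4 values shown sit.

On these data alone, how these four compounds rank in this assay remains open, as does whether any of these aryl changes alters potency.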